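Terminal amine variation on the butoxy-linked amide series

The compounds below may be only part of what the source reports. "The series", "measured", "known", "first", "only" and "open" are said of these compounds alone.

Measured compounds in a functional assay on the whole organism for antagonist activity, with Rattus norvegicus as the target; on this read-out higher numbers stand for an effect only at larger amounts of compound and lower numbers for an effect already at smaller amounts:
compound 1, `COc1cc(C(=O)N2CCCC(N(C)C)c3sccc32)ccc1NC(=O)c1ccccc1-c1ccccc1` — > 0.3 mg/kg.
compound 2, `CN1CCCN(C(=O)CCCOc2cc(C(=O)N3CCCCc4sccc43)ccc2NC(=O)c2ccccc2-c2ccccc2)CC1` — 0.008 mg/kg.
compound 3, `CN(C)CCN1CCCN(C(=O)c2ccc(NC(=O)c3ccccc3-c3ccccc3)cc2)c2ccsc21` — 0.31 mg/kg.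

Compound 1 gives > 0.3 mg/kg, which is a limit of this assay and not a number; as stated in the limit of > 0.3 mg/kg in this assay, at which 1 of the 3 values shown sits, one of the three entries sits there. Compound 2 gives the lowest of the two numbers in this assay; the nearest number is that of compound 3, and the gap between compound 2 and compound 3 lies beyond the scatter. For the measured compounds named here, no single-point step between measured compounds is available, so no measured step size guides the next change.

Compound 4, `CCN(CC)C1CCN(C(=O)CCCOc2cc(C(=O)N3CCCCc4sccc43)ccc2NC(=O)c2ccccc2-c2ccccc2)CC1`, is to be measured in this assay. It differs from compound 2 in one place: 4-(diethylamino)piperidin-1-yl in place of 4-methyl-1,4-diazepan-1-yl on a carbonyl carbon. The rest of the structure is unchanged. For this change a step from compound 2 to compound 4 of a 1.3-fold higher number from compound 2 to compound 4 (0.10 log units; within the scatter) is expected, which is no larger than the scatter in either direction. Compound 4 is therefore estimated at 0.01 mg/kg, with a range from 0.003 mg/kg to 0.04 mg/kg.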

Compound 4, dose for 50% inhibition: 0.01 mg/kg
The estimate for compound 4 equals the measured number at the digits printed; the measured number falls inside the stated range.
By their numbers in this assay, from the lowest: compounds 2 and 4 (each within the scatter of the next); then compound 3.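

In this assay, for the compounds shown here, 4-(diethylamino)piperidin-1-yl in place of 4-methyl-1,4-diazepan-1-yl on a carbonyl carbon whose other neighbour is a saturated chain carbon gives the first single-place step, a 1.3-fold higher number from compound 2 to compound 4 (0.10 log units; within the scatter), so this read-out does not separate the two groups. The position therefore accepts a six-membered ring with one hetero atom carrying a diethylamino group as well as a seven-membered ring with two hetero atoms, even with more heavy atoms in the entering group, and it does so without leaving the scatter. No measured property on hand bears on this result.

One step between two tertiary amine groups leaves open how far this position reaches: a morpholin-4-yl group, a primary amine or a carboxylic acid on the same carbonyl carbon could give a very different picture. Also open, on these data alone, is whether the 4-(diethylamino)piperidin-1-yl group keeps its place in the order with a longer chain to the carbonyl carbon.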